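The source may hold more compounds than are shown below. What is called first, only, known or untested is meant among the compounds shown, and "the series" means these compounds.

Measured so far in a functional assay on TK-10 cells (Homo sapiens) for inhibition, read by sulforhodamine B assay, with a stated time of 48 h; a higher number here means a weaker inhibitor of growth, a lower number a stronger inhibitor of growth:
compound 1 `Cc1ccc(C2=NN(c3ccc(S(C)(=O)=O)cc3)C(=O)CC2)cc1` gives 7690 nM
compound 2 `Cc1cc(O)ccc1C1=NN(c2ccc(S(C)(=O)=O)cc2)C(=O)CC1` gives 80500 nM

Among the compounds with values here, compound 2 holds the higher of the two numbers, and its gap to compound 1, its only neighbour, lies beyond the scatter. Compound 3 `CCc1ccc(C2=NN(c3ccc(S(C)(=O)=O)cc3)C(=O)CC2)cc1` is not yet measured. It carries 4-ethylphenyl in place of 4-hydroxy-2-methylphenyl on a carbon with a double bond to nitrogen and keeps the rest of the core.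

Within the data shown here, one measured step bears on this change, and it is large: a 10-fold higher number from compound 1 to compound 2 (1.02 log units; beyond the scatter) on exchange of 4-methylphenyl for 4-hydroxy-2-methylphenyl at that same carbon. The group that leaves now is the one that entered in that step. A large step of similar size is therefore expected, running the other way to a lower number. Among the measured compounds shown here, no measured compound carries 4-ethylphenyl, so the range is kept wide on both sides. The expected step is a 10-fold lower number from compound 2 to compound 3 (1.00 log units; beyond the scatter) and rests on that single comparison. Compound 3 is estimated at 8000 nM with an expected range from 3000 nM to 22000 nM for repeated measurements.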

Compound 3, concentration for 50% growth inhibition: 8310 nM
Compound 3: the middle estimate sits 1.0-fold (0.02 log units) below what was measured; the measured number falls inside the stated range.
By their numbers in this assay, from the lowest: compounds 1 and 3 (each within the scatter of the next); then compound 2.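

In this assay, 4-ethylphenyl in place of 4-hydroxy-2-methylphenyl on the carbon with a double bond to nitrogen gives a 9.7-fold lower number from compound 2 to compound 3 (0.99 log units; beyond the scatter) and so brings the number back to the level of compound 1 with a group other than 4-methylphenyl. Methyl in place of hydrogen on the saturated chain carbon bound to an aromatic carbon gives a 1.1-fold higher number from compound 1 to compound 3 (0.03 log units; within the scatter) and leaves no readable difference between 4-methylphenyl and 4-ethylphenyl at this position. Of the three groups shown, only 4-hydroxy-2-methylphenyl stands apart, and it is also the only one that counts a hydrogen-bond donor and a hydrogen-bond acceptor.

It stays open whether the hydroxy group or the ring methyl of that group accounts for the higher number, since neither 4-hydroxyphenyl nor 2-methylphenyl is among the compounds shown. As far as these compounds go, it also stays open how far the match between compound 1 and compound 3 extends, for instance to a longer chain such as 4-propylphenyl or to a phenyl ring carrying an amine or a carboxylic acid. No measurement is at hand that would explain any of these steps.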